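This account rests on a few compounds, and the source may have more. Where it says the series, first, only, none or still open, it means among the compounds named here.

Compound 1 `CCCC(C)n1ccc2cc(/C(C)=C/C(=O)Nc3ccccc3OCCCC(=O)O)ccc21` and compound 2 `CCCCC(C)n1ccc2cc(/C(C)=C/C(=O)Nc3ccccc3OCCCC(=O)O)ccc21` share one core and differ only in the chain on the aromatic nitrogen. In an assay on Prostate gland for inhibition of steroid 5-alpha-reductase (Rattus norvegicus) (a higher number here means a weaker inhibitor, a lower number a stronger inhibitor), compound 1 gives 7.8 nM, and compound 2 gives 6 nM, a difference of a 1.3-fold lower number from compound 1 to compound 2 (0.11 log units; within the scatter). Compound 2 thus gives the lower of the two numbers, though it stands within the scatter of compound 1. Compound 3 `CCCCCC(CCCCC)n1ccc2cc(/C(C)=C/C(=O)Nc3ccccc3OCCCC(=O)O)ccc21` carries 1-pentylhexyl in place of 1-methylpentyl on an aromatic nitrogen. Within the data shown here, the one step that bears on this change, a 1.3-fold lower number from compound 1 to compound 2 (0.11 log units; within the scatter), also lengthened the chain and stayed within the scatter. Compound 3 is therefore expected to show a 1.3-fold higher number from compound 2 to compound 3 (0.12 log units; within the scatter). For compound 3 the estimate is 8 nM, between 3 nM and 25 nM.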

Compound 3, half-maximal inhibitory concentration: 25 nM
Beside the measured number, compound 3's estimate is 3.1-fold (0.49 log units) below it; the measured number falls inside the stated range.
By their numbers in this assay, from the lowest: compounds 2 and 1 (each within the scatter of the next); then compound 3.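

On this aromatic nitrogen, the chain can matter in this assay: the earlier step stayed within the scatter, whereas 1-pentylhexyl, with 11 heavy atoms against 6 in 1-methylpentyl, gives a 4.2-fold higher number from compound 2 to compound 3 (0.62 log units; beyond the scatter) and, against the 1-methylbutyl group, a 3.2-fold higher number from compound 1 to compound 3 (0.51 log units; beyond the scatter). Even so, compound 3 remains a fairly modest step from the other two. Nothing here explains why the larger group gives the higher number. On these data alone, it remains open where along the way from 1-methylpentyl to 1-pentylhexyl the number starts to rise, and how a 1-propylbutyl chain or a cyclohexyl ring would behave here.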